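From 4-fluorobenzyl to 2,3-dichlorobenzyl: notes on compound 3

The source may hold more compounds than are shown below. What is called first, only, known or untested is meant among the compounds shown, and "the series" means these compounds.

Results so far in an ADME assay on J774.A1 cells (Mus musculus) for cytotoxicity, read by MTT assay, with a stated time of 48 h; a higher number here means that more compound is tolerated, a lower number that less compound is tolerated
- compound 1 `O=C(NCc1ccc(F)cc1)c1c([N+](=O)[O-])noc1-c1ccc([N+](=O)[O-])cc1` gives "not determined" (no result reported)
- compound 2 `O=C(NCc1ccc(F)cc1)c1c([N+](=O)[O-])noc1-c1ccc(Cl)cc1` gives 91900 nM

Going by the values given here, compound 2 holds the only number, so it cannot yet be ranked against any other compound. Compound 3 `O=C(NCc1cccc(Cl)c1Cl)c1c([N+](=O)[O-])noc1-c1ccc(Cl)cc1` keeps the shared core of compound 2 and carries 2,3-dichlorophenyl in place of 4-fluorophenyl on a saturated chain carbon bound to an amide-type nitrogen. Among the compounds with values here, no measured pair shows what a change at this place does, and the only anchor is compound 2 at 91900 nM. With so little to go on, no shift beyond the scatter is expected in this assay, and any small shift would more likely be toward less compound tolerated. The estimated step is a 1.3-fold lower number from compound 2 to compound 3 (0.12 log units; within the scatter). For compound 3 the expected value is 70000 nM, with an estimated range of 25000 nM to 160000 nM.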

Compound 3, half-maximal cytotoxic concentration: 73700 nM
The estimate for compound 3 lay 1.1-fold (0.02 log units) below the measured number; low and high end bracket the measured number.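

Going by these compounds alone, this is the first measured pair at this place, on a saturated chain carbon bound to an amide-type nitrogen: in this assay, 2,3-dichlorophenyl in place of 4-fluorophenyl gives a 1.2-fold lower number from compound 2 to compound 3 (0.10 log units; within the scatter). The read-out therefore does not separate these two aryl groups, and the exchange of 4-fluorobenzyl for 2,3-dichlorobenzyl leaves compound 3 level with compound 2 within the scatter. No measurement on hand offers an explanation for this result.

Within the data shown here, because this single pair covers only two halogenated aryl groups, it remains open what an amine, a carboxylic acid or a longer chain at this place would do in this assay. Compound 1 has no reported number, so the difference that separates it from compound 2 cannot be read.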